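The compounds below may be only part of what the source reports. "The series", "measured", "known", "first", "only" and "open" are said of these compounds alone.

Of the compounds shown here, three sharing one core have been measured in a functional assay on NCI/ADR-RES cells (Homo sapiens) for antiproliferative activity, with a stated time of 48 h; a higher number here means that more compound is tolerated, a lower number that less compound is tolerated. Compound 1 `Cc1cc(O)c(C2=NN(c3ccc(S(N)(=O)=O)cc3)C(c3ccccc3O)C2)cc1Cl` gives 54100 nM in this assay. Compound 2 `Cc1cc(O)c(C2=NN(c3ccc(S(N)(=O)=O)cc3)C(c3ccccc3Cl)C2)cc1Cl` gives 38800 nM. Compound 3 `Cc1cc(O)c(C2=NN(c3ccc(S(N)(=O)=O)cc3)C(/C=C/c3ccccc3)C2)cc1Cl` gives 53000 nM, which places it second highest of the three, with compound 1 nearest and compound 2 furthest, both inside the scatter.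

The next compound, compound 4 `COc1ccc(C2CC(c3cc(Cl)c(C)cc3O)=NN2c2ccc(S(N)(=O)=O)cc2)cc1OC`, differs from compound 3 only at the saturated ring carbon of the five-membered non-aromatic ring: 3,4-dimethoxyphenyl in place of 2-phenylethenyl on a saturated ring carbon.

Among the compounds with values here, two measured steps bear on this change, as both alter the same saturated ring carbon. The step of a 1.0-fold lower number from compound 1 to compound 3 (0.01 log units; within the scatter) and the step of a 1.4-fold higher number from compound 2 to compound 3 (0.14 log units; within the scatter) were each within the scatter, so replacing the group on that carbon, whether by 2-hydroxyphenyl, 2-chlorophenyl or 2-phenylethenyl, has not moved the read-out beyond what repeated measurements would show. The remaining step, a 1.4-fold lower number from compound 1 to compound 2 (0.14 log units; within the scatter), concerns the aromatic carbon and is also within the scatter.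

On this basis no shift beyond the scatter is expected for compound 4, and the step of a 1.1-fold lower number from compound 3 to compound 4 (0.03 log units; within the scatter) is estimated to be small. Compound 4 is therefore expected to give about 50000 nM in this assay, with a range from 25000 nM to 100000 nM.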

Compound 4, concentration lethal to 50% of the cells: > 100000 nM
Compound 4: only a limit was reported; the forecaster's own chance of this, stated with the estimate: 10%; middle value at least 2.0-fold (0.30 log units) from the limit.
By their numbers in this assay, from the lowest: compounds 2, 3 and 1 (each within the scatter of the next). At a limit, above all of these: compound 4.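

In this assay compound 4 is reported only as a limit of the assay and not as a number: the limit of > 100000 nM in this assay, at which 1 of the 4 values shown sits.

Within the data shown here, the saturated ring carbon had so far given only steps within the scatter among 2-hydroxyphenyl, 2-chlorophenyl and 2-phenylethenyl, but with 3,4-dimethoxyphenyl it gives an at least 2.5-fold higher number from compound 2 to compound 4 (0.41 log units; beyond the scatter), the first step at this position that is printed as beyond the scatter. From the compounds shown here alone, the other two steps, an at least 1.8-fold higher number from compound 3 to compound 4 (0.27 log units; that floor lies within the scatter) and an at least 1.8-fold higher number from compound 1 to compound 4 (0.26 log units; that floor lies within the scatter), have floors that lie within the scatter, so the evidence that this change matters rests on the comparison with 2-chlorophenyl alone, and the true size of all three steps remains unknown.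

The compounds shown leave open how far the number for compound 4 lies beyond its limit, and whether both methoxy groups of the 3,4-dimethoxyphenyl are needed for the step or one would give the same. They also leave open what a 4-methoxyphenyl, a dimethylamino group or a carboxylic acid on that saturated ring carbon would give in this assay.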